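The compounds below may be only part of what the source reports. "The series", "measured", "known", "first", "only" and "open" are said of these compounds alone.

Measured compounds in a functional assay on U-87MG ATCC cells for antiproliferative activity against U-87 MG (Homo sapiens), read by MTT assay, with a stated time of 48 h, tested at 50 uM; on this read-out higher numbers stand for a weaker effect at the one concentration tested and lower numbers for a stronger effect:
compound 1 `COc1ccc(-c2nc(C)c(C(=O)CSc3nc(-c4ccc(OC)cc4)c(C#N)c(=O)[nH]3)s2)cc1` gives 32.6%
compound 2 `COc1ccc(-c2nc(C)c(C(=O)CSc3nc(-c4ccc(OC)c(OC)c4)c(C#N)c(=O)[nH]3)s2)cc1` gives 22.2%
compound 3 `Cc1nc(-c2ccccc2)sc1C(=O)CSc1nc(-c2ccc(Cl)c(Cl)c2)c(C#N)c(=O)[nH]1` gives 75.3%

Compound 3 stands highest of the three in this assay, beyond the scatter from both compound 1 and compound 2, so its effect at the one concentration is the weakest shown. Compound 4 `COc1ccc(-c2nc(C)c(C(=O)CSc3nc(-c4ccc(Cl)c(Cl)c4)c(C#N)c(=O)[nH]3)s2)cc1` is not yet measured. It differs from compound 3 by methoxy in place of hydrogen on an aromatic carbon.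

Going by the values given here, one measured step bears on this change in kind: a number 10.4 percentage points lower from compound 1 to compound 2 (beyond the scatter), also a methoxy in place of hydrogen on an aromatic carbon, though on the other aromatic ring of the shared core and with different neighbouring groups. Among the compounds with values here, compound 3 differs from compound 1 in more than one place, so that pair gives no clean step. On the basis of the step from compound 1 to compound 2, a modest lowering of the number is expected, with wide uncertainty because the place of the change is not the same.

Compound 4 is therefore expected to give 63% in this assay, within 43% to 83%, an expected step of a number 12.3 percentage points lower from compound 3 to compound 4 (beyond the scatter).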

Compound 4, a percentage reported as activity, at one concentration (the size of the read-out at that concentration, not a potency): 78.4%
The estimate for compound 4 lay 15.4 percentage points below the measured number; measured number inside the range.
By their numbers in this assay, from the lowest: compound 2; then compound 1; then compounds 3 and 4 (each within the scatter of the next).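

In this assay, going by these compounds alone, adding the methoxy to give phenyl to 4-methoxyphenyl on the core of compound 3 produces no step that stands clear of the scatter: a number 3.1 percentage points higher from compound 3 to compound 4 (within the scatter). With that 4-methoxyphenyl held constant, the large steps come from the other aromatic ring, where 3,4-dichlorophenyl in place of 3,4-dimethoxyphenyl gives a number 56.2 percentage points higher from compound 2 to compound 4 (beyond the scatter), and 3,4-dichlorophenyl in place of 4-methoxyphenyl gives a number 45.8 percentage points higher from compound 1 to compound 4 (beyond the scatter). The two methoxy steps on their different cores cannot be told apart: the same change on two cores in this assay, a number 10.4 percentage points lower (beyond the scatter) from compound 1 to compound 2 and a number 3.1 percentage points higher (within the scatter) from compound 3 to compound 4, 13.5 percentage points apart, within the scatter of two such steps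

Going by these compounds, it remains open whether a single chlorine at either ring position would account for the large steps seen with 3,4-dichlorophenyl. Also open, on these data alone, is how an amine or a carboxylic acid in place of the methoxy on the 4-methoxyphenyl would read in this assay.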